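Dichlorophenyl addition and cell toxicity in a sulfonate series

The source may report more compounds than this note shows. Statements on the series, on what has been measured and on what is new or still open speak of the compounds shown alone.

Compound 1, `CCC1(Cc2ccccc2)OS(=O)(=O)CC1=O`, in an ADME assay on HEL cells (Homo sapiens) for cytotoxicity, with a stated time of 3 days (on this read-out higher numbers stand for lower toxicity in this test and lower numbers for higher toxicity in this test), gives > 100000 nM, which is a limit of the assay rather than a number.
Compound 2, `CCC1(Cc2ccccc2)OS(=O)(=O)C=C1OC`, in this assay gives > 400000 nM, again only a limit.
Compound 3, `CCC1(Cc2ccccc2)OS(=O)(=O)C=C1NCc1ccccc1`, in this assay gives >= 80000 nM, also a limit.

Compound 2 thus stands at a limit only, and the two other values shown are limits as well, so none of the three can be placed in order against another. Within the data shown here, one measured step touches compound 2: a step that the two limits leave unreadable from compound 2 to compound 3. Its size cannot be read because the limit of > 400000 nM in this assay, at which 1 of the 3 values shown sits, and the limit of >= 80000 nM in this assay, at which 1 of the 3 values shown sits, are each only a limit, leaving the change on a double-bonded ring carbon without a readable effect.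

Compound 4, `CCC1(Cc2ccccc2)OS(=O)(=O)C=C1OCc1ccc(Cl)c(Cl)c1`, differs from compound 2 by 3,4-dichlorophenyl in place of hydrogen on a saturated chain carbon bound to an oxygen on an unsaturated carbon. Among the measured compounds shown here, no measured step carries this change, so no size in either direction can be expected beyond a reading that most likely ends at a limit once more. Compound 4 is therefore expected to give about 200000 nM, with a range from 50000 nM to 400000 nM. The step of an at least 2.0-fold lower number from compound 2 to compound 4 (0.30 log units; that floor lies within the scatter) is expected to stay within the scatter, if it can be read at all.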

Compound 4, minimum cytotoxic concentration: >= 20000 nM
Compound 4 was reported as a limit (the forecaster's own chance of this, stated with the estimate: 80%); the middle value does not contradict the limit.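

In this assay compound 4 gives >= 20000 nM, which is a limit of the assay and not a number. Compound 2 gives > 400000 nM, also only a limit, so the step between compound 2 and compound 4 cannot be read. The compounds shown leave open whether 3,4-dichlorophenyl in place of hydrogen changes cell toxicity at all.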